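This account rests on a few compounds, and the source may have more. Where it says the series, first, only, none or still open, it means among the compounds named here.

In a functional assay on P815 cells (Mus musculus) for antiproliferative activity (a lower number here means a stronger inhibitor, a higher number a weaker inhibitor), compound 1, with the structure `Nc1nc(=O)n(C2OC(CO)C(I)C2O)cc1F`, gives 0.1 ug/mL. Among the measured compounds shown here, this is the higher of the two numbers measured so far, so compound 1 is the weaker of the two inhibitors. The other measured compound, compound 2, has the structure `CS(=O)(=O)O[C@@H]1[C@@H](O)[C@H](n2cc(F)c(N)nc2=O)O[C@@H]1CO`; in this assay compound 2 gives 0.02 ug/mL, a number lower by a margin beyond the usual scatter, so compound 2 is the stronger of the pair.

Compound 3, with the structure `Nc1nc(=O)n(C2OC(CO)C(Cl)C2O)cc1F`, is not yet measured. It differs from compound 1 in one place: chloro in place of iodo on a saturated ring carbon. For the measured compounds named here, no pair of measured compounds shows what exchanging one halogen for another does in this assay, so nothing here fixes the size or direction of the step. The expected step of a 1.5-fold higher number from compound 1 to compound 3 (0.18 log units; within the scatter) is therefore small, not beyond the scatter. For compound 3 the expected value in this assay is 0.15 ug/mL, with a range from 0.03 ug/mL to 0.7 ug/mL.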

Compound 3, concentration for 50% inhibition: 0.7 ug/mL
Estimate against measurement, compound 3: 4.7-fold (0.67 log units) below, and the stated range covers the measured number.
By their numbers in this assay, from the lowest: compound 2; then compound 1; then compound 3.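

Chloro in place of iodo on this saturated ring carbon gives a 7.0-fold higher number from compound 1 to compound 3 (0.85 log units; beyond the scatter) in this assay, so compound 3 is the weaker inhibitor and a swap of one halogen for another at this position is enough to move the number beyond the scatter. The two groups have the same counts of heavy atoms, hydrogen-bond donors and acceptors, and the same net charge, so those counts do not separate them. No measurement shown here explains the size of this step.

As far as these compounds go, how bromo or fluoro would fall at this ring carbon remains open, and with it whether the halogens follow any order at all. From the compounds shown here alone, what an amine or a methyl group would do at the same place also remains open.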